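Swapping 2-(methylsulfanyl)ethyl for furan-2-yl in a cytotoxicity series

The compounds below may be only part of what the source reports. "The series", "measured", "known", "first", "only" and "open" are said of these compounds alone.

In an ADME assay on BHK cells (Mesocricetus auratus) for cytotoxicity, read by MTT assay, with a stated time of 96 h (on this read-out lower numbers stand for higher toxicity in this test and higher numbers for lower toxicity in this test), compound 1 (`FC(F)(F)c1cccc(NC(=S)Nc2cccc(Br)c2)c1`) gives 10000 nM. Compound 2 (`C=C(C)CNC(=S)Nc1cccc(C(F)(F)F)c1`) reads > 100000 nM, which is a limit of the assay. Compound 3 (`CSCCCNC(=S)Nc1cccc(C(F)(F)F)c1`) reads > 100000 nM, also a limit. Compound 4 (`FC(F)(F)c1cccc(NC(=S)NCc2ccco2)c1`) has furan-2-yl in place of 2-(methylsulfanyl)ethyl on a saturated chain carbon bound to an amide-type nitrogen. Among the compounds with values here, two measured steps bear on this: an at least 10-fold higher number from compound 1 to compound 2 (1.00 log units; beyond the scatter) and an at least 10-fold higher number from compound 1 to compound 3 (1.00 log units; beyond the scatter), both replacing 3-bromophenyl with an open chain. The limits leave a step that the two limits leave unreadable from compound 2 to compound 3. Compound 4 regains an aromatic ring, as compound 1 with 10000 nM has, but on a saturated chain carbon, so only a small drop is expected. The expected change is an at least 1.2-fold lower number from compound 3 to compound 4 (0.09 log units; that floor lies within the scatter). Compound 4 is estimated at 80000 nM, within a range of 25000 nM to 100000 nM.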

Compound 4, half-maximal cytotoxic concentration: 48000 nM
Compound 4: middle estimate off by 1.7-fold (0.22 log units), on the high side; measured number inside the range.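

In this assay, a ring at this place on the saturated chain carbon gives a number that is not a limit, with an at least 2.0-fold lower number from compound 3 to compound 4 (0.31 log units; beyond the scatter) and an at least 2.0-fold lower number from compound 2 to compound 4 (0.31 log units; beyond the scatter). The ring still does not match the 3-bromophenyl of compound 1, with a 4.8-fold higher number from compound 1 to compound 4 (0.68 log units; beyond the scatter), so the series now has a middle value. The first two steps are floors only: the limit of > 100000 nM in this assay, at which 2 of the 4 values shown sit.

From the compounds shown here alone, whether the furan oxygen matters stays open, as a phenyl ring or a thiophene at this place would be needed to tell, and whether a longer chain between ring and nitrogen moves the number is also unresolved.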